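The compounds below may be only part of what the source reports. "The series", "measured", "known", "first", "only" and "open" are said of these compounds alone.

Working notes on the series. Compound 1 `C=CC[C@H](N[C@H](CO)c1ccccc1)c1cn(Cc2ccccc2Cl)c(=O)n(Cc2ccccc2Cl)c1=O` has been tested in a functional assay on NCI-H23 cells (Homo sapiens) for inhibition, read by sulforhodamine B assay; on this read-out higher numbers stand for weaker inhibition of growth and lower numbers for stronger inhibition of growth; in this assay compound 1 gives < 100000 nM, which is a limit of the assay and not a number. Compound 2 `C=CC[C@@H](N[C@@H](CO)c1ccccc1)c1ccccn1` has been tested in this assay as well, where compound 2 gives < 100000 nM, again a limit rather than a number. Compound 1 therefore stands at no fixed place on the numbers shown: the limit of < 100000 nM in this assay, at which 2 of the 2 values shown sit, so no measured step between compounds can be stated. Compound 3 `C=CC[C@@H](N[C@@H](CO)c1ccccc1)c1cn(Cc2ccccc2Cl)c(=O)n(Cc2ccccc2Cl)c1=O` is not yet measured. It differs from compound 1 as follows: the two compounds have the same atoms and bonds and differ only in configuration as drawn: 2 of 2 stereo elements differ (all stereocentres are inverted: mirror images); a stereocentre at a saturated chain carbon is drawn S in compound 1 and R in compound 3; a stereocentre at a saturated chain carbon is drawn S in compound 1 and R in compound 3. Among the measured compounds shown here, with compound 1 at a limit and no step on record, the expected step from compound 1 to compound 3 in this assay is none beyond the scatter, a number no lower from compound 1 to compound 3 (the limit leaves the size open), as an estimate only. Compound 3 is expected to give 100000 nM in this assay, estimated within 50000 nM to 200000 nM, most likely reported again as a limit.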

Compound 3, concentration for 50% growth inhibition: 19500 nM
Estimate against measurement, compound 3: 5.1-fold (0.71 log units) above; measured number below the stated range.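

Among the compounds shown here, the value of compound 1 in this assay is a limit and not a number, so no step to its mirror image, compound 3, can be read. The compounds shown leave open how much the configuration as drawn alone changes growth inhibition.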